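A Methoxy Added Twice in a Microsomal Stability Series

The compounds below may be only part of what the source reports. "The series", "measured", "known", "first", "only" and "open" are said of these compounds alone.

Compound 1 `Cc1ccc([C@H](C)NC(=O)Cn2nnc3ccccc3c2=O)cc1`: < 9.9 mL/min/kg
Compound 2 `COc1cc(C)ccc1[C@H](C)NC(=O)Cn1nnc2ccccc2c1=O`: 30 mL/min/kg
Compound 3 `C[C@H](NC(=O)Cn1nnc2ccccc2c1=O)c1ccc(OC(F)(F)F)cc1F`: < 9.9 mL/min/kg

In an ADME assay on microsomes from liver (Homo sapiens) for metabolic stability (a lower number here means slower removal, a higher number faster removal of the compound), compound 1 gives < 9.9 mL/min/kg, which is a limit of the assay and not a number. Compound 2 gives 30 mL/min/kg. Compound 3 gives < 9.9 mL/min/kg, again a limit. Within the data shown here, the one measured step is an at least 3.0-fold higher number from compound 1 to compound 2 (0.48 log units; beyond the scatter), made by methoxy in place of hydrogen on an aromatic carbon. Compound 4 `COc1cccc2nnn(CC(=O)N[C@@H](C)c3ccc(OC(F)(F)F)cc3F)c(=O)c12` has not been measured; it carries methoxy in place of hydrogen on an aromatic carbon. This is the same kind of change as from compound 1 to compound 2, not the same: in compound 2 the methoxy sits ortho to a large group and meta to a methyl group, whereas in compound 4 it sits on a ring that is part of a fused or bridged system of two rings, ortho to a fused ring and meta to a fused ring. The difference between the cores of compound 1 and compound 3 is not broken down here. Notable is the limit of < 9.9 mL/min/kg in this assay, at which 2 of the 3 values shown sit. For compound 4 a step of an at least 2.0-fold higher number from compound 3 to compound 4 (0.30 log units; that floor lies within the scatter) is expected, resting on the step of an at least 3.0-fold higher number from compound 1 to compound 2 (0.48 log units; beyond the scatter). Compound 4 is therefore estimated at 20 mL/min/kg.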

Compound 4, clearance: 41 mL/min/kg
For compound 4 the middle estimate is 2.1-fold (0.31 log units) below the measured one; measured number inside the range.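

In this assay, methoxy in place of hydrogen on an aromatic carbon brings an at least 4.1-fold higher number from compound 3 to compound 4 (0.61 log units; beyond the scatter), here on a six-membered aromatic ring that is part of a fused or bridged system of two rings. The number therefore moves the same way on both cores, although the methoxy stands in a different place on each, and the two pairs can be set side by side: the same change on two cores in this assay, an at least 3.0-fold higher number (0.48 log units; beyond the scatter) from compound 1 to compound 2 and an at least 4.1-fold higher number (0.61 log units; beyond the scatter) from compound 3 to compound 4; the limit leaves it open whether they differ What this does not show is the true size of either step, or whether the change would go the same way on any further core, since each of the two steps starts from a limit: the limit of < 9.9 mL/min/kg in this assay, at which 2 of the 4 values shown sit.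

The compounds shown leave open how a hydroxyl or an ethoxy group on the same aromatic carbons would read in this assay, and so whether the rise is tied to the methoxy itself. They also leave open what a methoxy would do on the other carbons of the same ring.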